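Fluoro step from compound 2 to compound 3

The source may report more compounds than this note shows. Statements on the series, on what has been measured and on what is new or still open speak of the compounds shown alone.

In a functional assay on A549 cells (Homo sapiens) for antiproliferative activity, with a stated time of 72 h (a lower number here means a stronger inhibitor, a higher number a weaker inhibitor), compound 1 (`Cc1[nH]c2ccccc2c1C1=CCN(Cc2ccc(OCC(=O)NO)cc2)CC1`) gives 615 nM and compound 2 (`Cc1[nH]c2ccccc2c1C1=CCC(NCc2ccc(OCC(=O)NO)cc2)CC1`) gives 187 nM as the lower of the two numbers, with a gap beyond the scatter. Compound 3 (`Cc1[nH]c2ccccc2c1C1=CCC(NCc2ccc(OCC(=O)NO)cc2F)CC1`) differs from compound 2 by fluoro in place of hydrogen on an aromatic carbon with fluoro in place of hydrogen on an aromatic carbon, ortho to a large group. Among the measured compounds shown here, no measured pair shows this change, so the expectation rests on compound 2 alone. Expected in this assay is a 1.1-fold lower number from compound 2 to compound 3 (0.04 log units; within the scatter) with no change beyond the scatter. Compound 3 is estimated at 170 nM with an expected range from 75 nM to 380 nM in this assay.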

Compound 3, half-maximal inhibitory concentration: 130 nM
Compound 3: the middle estimate sits 1.3-fold (0.12 log units) above what was measured; measured number inside the range.
By their numbers in this assay, from the lowest: compounds 3 and 2 (each within the scatter of the next); then compound 1.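

In this assay, fluoro in place of hydrogen on an aromatic carbon, ortho to a large group and meta to a (hydroxycarbamoyl)methoxy group, gives a 1.4-fold lower number from compound 2 to compound 3 (0.16 log units; within the scatter) and so leaves the number within the scatter. This first single-place step in the series shows that this position takes fluoro without a change beyond the scatter, for this one atom only. No measurement at hand bears on the reason for this result.

As far as these compounds go, whether chlorine, a methoxy group or an amine at this position would shift the number beyond the scatter stays open. Also open, from the compounds shown here alone, is how fluoro behaves on the other carbons of this aromatic ring.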